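The compounds below may be only part of what the source reports. "The series", "measured", "known", "first", "only" and "open" are said of these compounds alone.

Working notes on the series. In a functional assay on A549 cells (Homo sapiens) for antiproliferative activity, read by MTT assay, with a stated time of 72 h (a lower number here means a stronger inhibitor, a higher number a weaker inhibitor), compound 1 (`O=C(CCCCCCc1nc(-c2ccccc2Cl)no1)NO`) gives 8870 nM and compound 2 (`O=C(CCCCCCc1nc(-c2cccc([N+](=O)[O-])c2)no1)NO`) gives 10800 nM, so these two sit within the scatter of each other. Compound 3 (`O=C(CCCCCCc1nc(-c2cccs2)no1)NO`) gives 4370 nM, and compound 1 is separated from it by a modest step, a 2.0-fold lower number from compound 1 to compound 3 (0.31 log units; beyond the scatter).

Compound 4 (`Nc1ccccc1NC(=O)CCCCCCc1nc(-c2ccccc2Cl)no1`) carries 2-aminophenyl in place of hydroxy on an amide-type nitrogen. Among the compounds with values here, the only measured single change, a 2.0-fold lower number from compound 1 to compound 3 (0.31 log units; beyond the scatter), is a swap on an aromatic carbon. Within the data shown here, it shows how far this readout moved in one case, but no measured compound changes the amide-type nitrogen. The direction is therefore a judgement with weak support, and the range must stay wide.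

A moderate move to a higher number in this assay is expected, somewhat larger than that modest step, and it is estimated as a 1.8-fold higher number from compound 1 to compound 4 (0.26 log units; within the scatter). For compound 4 the expected value is 16000 nM, with an estimated range from 4500 nM to 55000 nM.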

Compound 4, half-maximal inhibitory concentration: > 100000 nM
Compound 4 ended at the assay's limit; the forecaster's own chance of this, stated with the estimate: 15%; middle value at least 6.2-fold (0.79 log units) away from the limit.
By their numbers in this assay, from the lowest: compound 3; then compounds 1 and 2 (each within the scatter of the next). At a limit, above all of these: compound 4.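

Within the data shown here, at the amide-type nitrogen, 2-aminophenyl in place of hydroxy gives an at least 11-fold higher number from compound 1 to compound 4 (1.05 log units; beyond the scatter), the first large step and one that clearly exceeds the only earlier step, the swap on an aromatic carbon, a 2.0-fold lower number from compound 1 to compound 3 (0.31 log units; beyond the scatter). In this assay compound 4 stands at a limit of the assay and not at a number: the limit of > 100000 nM in this assay, at which 1 of the 4 values shown sits. On these data alone, the true size of this step therefore stays unknown, but with the core of compound 1, hydroxy on this nitrogen cannot be exchanged for 2-aminophenyl without a large move to a higher number.

As far as these compounds go, it remains open whether the same exchange does the same with the cores of compound 2 and compound 3. From the compounds shown here alone, it is also open how a plain phenyl or a methyl on this nitrogen would read, and so whether the step follows the ring or its amine.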